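Adding a second (dibutylamino)methyl group to compound 2

The source may report more compounds than this note shows. Statements on the series, on what has been measured and on what is new or still open speak of the compounds shown alone.

In a functional assay on MCF7 cells (Homo sapiens) for antiproliferative activity, read by MTT assay, with a stated time of 48 h (a higher number here means a weaker inhibitor, a lower number a stronger inhibitor), compound 1 `CN1CCN(Cc2ccc3c(c2O)-c2ccc(cc2O)CCc2ccc(O)c(c2)Oc2ccc(cc2)CC3)CC1` gives 6020 nM as a measured number. Compound 2 `CCCCN(CCCC)Cc1ccc2c(c1O)-c1ccc(cc1O)CCc1ccc(O)c(c1)Oc1ccc(cc1)CC2` gives > 20000 nM as a limit of the assay and not a number. Compound 2 therefore stands at the limit (the limit of > 20000 nM in this assay, at which 1 of the 2 values shown sits) with no exact value.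

Compound 3 `CCCCN(CCCC)Cc1cc2cc(c1O)Oc1ccc(cc1)CCc1ccc(CN(CCCC)CCCC)c(O)c1-c1ccc(cc1O)CC2` differs from compound 2 by one change ((dibutylamino)methyl in place of hydrogen on an aromatic carbon): (dibutylamino)methyl in place of hydrogen on an aromatic carbon, ortho to a hydroxy group. For the measured compounds named here, only one measured step bears on this, dibutylamino in place of 4-methylpiperazin-1-yl (an at least 3.3-fold higher number from compound 1 to compound 2 (0.52 log units; beyond the scatter)), and its size is a lower bound. Going by the values given here, that single step, which ends at compound 2, went toward a higher number, and no measured compound shows a change at the new place. No lower number is therefore expected in this assay, and no step beyond the scatter is expected (a step that the limit leaves unreadable from compound 2 to compound 3) either, with another report at the limit quite possible. For compound 3 the estimated value is 22000 nM as the middle, with an expected range from 9000 nM to 50000 nM as its span.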

Compound 3, half-maximal inhibitory concentration: > 20000 nM
Compound 3 ended at the assay's limit; the forecaster's own chance of this, stated with the estimate: 60%; the middle value is on the limit's open side.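

In this assay, compound 2 and compound 3 both end at a limit of the assay and not at a number, so no step can be read between them: the limit of > 20000 nM in this assay, at which 2 of the 3 values shown sit.

The compounds shown leave open whether (dibutylamino)methyl in place of hydrogen on an aromatic carbon, ortho to a hydroxy group, changes the result in this assay at all.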